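The source may hold more compounds than are shown below. What is called first, only, known or untested is meant among the compounds shown, and "the series" means these compounds.

Series notes. Compound 1 `Cc1cnc(Nc2ccc(S(N)(=O)=O)cc2)nc1Nc1nc2ccccc2s1` gives only a limit in a functional assay on PC-3 cells (Homo sapiens) for antiproliferative activity, read by MTT assay, with a stated time of 48 h (a higher number here means a weaker inhibitor, a lower number a stronger inhibitor), namely > 50000 nM. Compound 2 `Cc1cnc(Nc2ccc(S(C)(=O)=O)cc2)nc1Nc1nc2ccc(F)cc2s1` likewise returns a limit in this assay, > 50000 nM. Within the data shown here, compound 3 `NS(=O)(=O)c1ccc(Nc2nccc(Nc3nc4ccc(F)cc4s3)n2)cc1` is the single compound with a measured number: in this assay compound 3 gives 920 nM, so it stands alone, the other two sitting at the limit of > 50000 nM in this assay, at which 2 of the 3 values shown sit. Both compounds at that limit carry a methyl on the shared core, which compound 3 lacks. Compound 4 `Cc1cnc(Nc2ccc(S(N)(=O)=O)cc2)nc1Nc1nc2ccc(F)cc2s1` is not yet measured; it differs from compound 3 by methyl in place of hydrogen on an aromatic carbon. Among the measured compounds shown here, no measured pair isolates this change. The step from compound 3 to compound 4 is expected to be a loss, a 16-fold higher number from compound 3 to compound 4 (1.21 log units; beyond the scatter), well beyond the scatter. Compound 4 is estimated at 15000 nM, within 2500 nM to 50000 nM, possibly returning only a limit.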

Compound 4, half-maximal inhibitory concentration: 6980 nM
Compound 4: middle estimate off by 2.1-fold (0.33 log units), on the high side, and the stated range covers the measured number.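

In this assay, the methyl on the aromatic carbon of the shared core now has a measured size (a step of a 7.6-fold higher number from compound 3 to compound 4 (0.88 log units; beyond the scatter)), and compound 4 still gives a number with that methyl present. With the methyl kept, both the sulfonyl amino group (an at least 7.1-fold lower number from compound 2 to compound 4 (0.85 log units; beyond the scatter)) and the fluoro group (an at least 7.1-fold lower number from compound 1 to compound 4 (0.85 log units; beyond the scatter)) mark real gains, each step being read against a limit and not a number. Compound 1 and compound 2 each give only a limit: the limit of > 50000 nM in this assay, at which 2 of the 4 values shown sit.

Open, from the compounds shown here alone, is how a chlorine or an ethyl would compare with methyl at this position. Going by these compounds, the true size of both gains also stays open.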